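A few compounds are considered here, and "the series" means these few. Any claim that something is new, unique, unknown or untested is made for them only; others in the source may bear on it.

Compound 1 `O=C(O)CN1C(=O)/C(=C/c2nc3ccccc3n2Cc2ccc([N+](=O)[O-])cc2)SC1=S`: 7760 nM
Compound 2 `O=C(O)CN1C(=O)/C(=C/c2nc3ccccc3n2Cc2ccc(Cl)cc2)SC1=S`: 5580 nM
Compound 3 `O=C(O)CN1C(=O)/C(=C/c2nc3ccccc3n2Cc2ccc(C(F)(F)F)cc2)SC1=S`: 12500 nM

In a functional assay on MDA-MB-231 cells (Homo sapiens) for cytotoxicity, read by MTT assay, with a stated time of 48 h (on this read-out lower numbers stand for stronger inhibition and higher numbers for weaker inhibition), compound 1 gives 7760 nM, the middle of the three numbers. Its two measured steps are a 1.4-fold lower number from compound 1 to compound 2 (0.14 log units; within the scatter) and a 1.6-fold higher number from compound 1 to compound 3 (0.21 log units; within the scatter). Compound 4 `O=C(O)CN1C(=O)/C(=C/c2nc3ccccc3n2Cc2ccccc2F)SC1=S` differs from compound 1 as follows: 2-fluorophenyl in place of 4-nitrophenyl on a saturated chain carbon bound to an aromatic nitrogen. In words, this is 2-fluorophenyl in place of 4-nitrophenyl on a saturated chain carbon bound to an aromatic nitrogen. The nearest evidence is the set of group swaps on an aromatic carbon, the widest being a 2.2-fold higher number from compound 2 to compound 3 (0.35 log units; beyond the scatter), which is modest. Going by the values given here, no measured compound carries 2-fluorophenyl, so no step beyond the scatter is expected in this assay. The expected change is a 1.0-fold higher number from compound 1 to compound 4 (0.01 log units; within the scatter). For compound 4 the estimated value is 8000 nM, with an expected range from 3500 nM to 18000 nM.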

Compound 4, half-maximal inhibitory concentration: 330 nM
For compound 4 the middle estimate is 24-fold (1.38 log units) above the measured one; measured number outside the range, below it.
By their numbers in this assay, from the lowest: compound 4; then compounds 2, 1 and 3 (each within the scatter of the next, the first and the last beyond it).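

In this assay the swaps among nitro, chloro and trifluoromethyl on the aromatic carbon had changed the number modestly at most. The saturated chain carbon bound to an aromatic nitrogen proves far more sensitive: 2-fluorophenyl gives a 24-fold lower number from compound 1 to compound 4 (1.37 log units; beyond the scatter) and a 17-fold lower number from compound 2 to compound 4 (1.23 log units; beyond the scatter) and also a 38-fold lower number from compound 3 to compound 4 (1.58 log units; beyond the scatter) in the same place. No available evidence accounts for this gain. On these data alone, whether it belongs to the fluorine or to its place on the ring stays open, as does whether 2-chlorophenyl or 2-methoxyphenyl would keep it.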